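A few compounds are considered here, and "the series" means these few. Any claim that something is new, unique, unknown or untested is made for them only; others in the source may bear on it.

Compound 1 `CC(C)(C)c1cc(NC(=O)[C@@H]2CCCCN2Cc2ccc(Cl)cc2)no1` stands at the bottom of the measured set. In a physicochemical assay for solubility, read by HPLC, at pH 6.8 (a higher number here means a more soluble compound, a lower number a less soluble compound), compound 1 gives < 0.1 ug/mL, which is a limit of the assay rather than a number. Compound 2 `CC(C)(C)c1cc(NC(=O)[C@@H]2CCCCN2C2CC2)no1` gives 38 ug/mL in this assay, and compound 3 `CC(C)(C)c1cc(NC(=O)[C@@H]2CCCCN2C(=O)CC2CCOCC2)no1` gives 52 ug/mL. The two measured steps away from the 4-chlorobenzyl group, an at least 380-fold higher number from compound 1 to compound 2 (2.57 log units; beyond the scatter) and an at least 520-fold higher number from compound 1 to compound 3 (2.71 log units; beyond the scatter), are both large and point the same way. Compound 4 `CC(C)(C)c1cc(NC(=O)[C@@H]2CCCCN2C(=O)N2CCCCC2)no1` carries a change of the same kind at the same site: (piperidin-1-yl)carbonyl in place of 4-chlorobenzyl on an amine nitrogen in a ring. For compound 4 a step of comparable size is therefore expected, an at least 400-fold higher number from compound 1 to compound 4 (2.60 log units; beyond the scatter). Compound 4 is estimated to give 40 ug/mL in this assay, with a range from 10 ug/mL to 150 ug/mL.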

Compound 4, solubility: 49 ug/mL
Estimate against measurement, compound 4: 1.2-fold (0.09 log units) below; low and high end bracket the measured number.
By their numbers in this assay, from the lowest: compounds 2, 4 and 3 (each within the scatter of the next). At a limit, below all of these: compound 1.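

Placing (piperidin-1-yl)carbonyl on the amine nitrogen in a ring gives an at least 490-fold higher number from compound 1 to compound 4 (2.69 log units; beyond the scatter), so a third replacement of 4-chlorobenzyl also ends up far from compound 1. The replacements do not separate from one another, with a 1.1-fold lower number from compound 3 to compound 4 (0.03 log units; within the scatter) and a 1.3-fold higher number from compound 2 to compound 4 (0.11 log units; within the scatter). Compound 1 stands at a limit, so its steps are bounds only: the limit of < 0.1 ug/mL in this assay, at which 1 of the 4 values shown sits.

The compounds shown leave open whether the chlorine or the benzyl group itself accounts for the gap, which plain benzyl would address. They also leave open whether a carboxylic acid or an amine on this nitrogen would reach beyond this shared level.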